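This account rests on a few compounds, and the source may have more. Where it says the series, first, only, none or still open, it means among the compounds named here.

In an ADME assay on HEK293 cells (Homo sapiens) for cytotoxicity, with a stated time of 72 h (a higher number here means that more compound is needed for the effect, a lower number that less compound is needed), compound 1, `C=C[C@@](C)(/C=C/c1ccc(OC)cc1)CCC=C(C)C`, gives > 36600 nM, which is a limit of the assay and not a number. Compound 2, `C=C[C@@](C)(/C=C/c1ccc(O)cc1)CC/C=C(C)/C=C/C(=O)OCC`, gives > 36600 nM, which is also a limit. Among the compounds with values here, the two compounds therefore share one reading, (the limit of > 36600 nM in this assay, at which 2 of the 2 values shown sit), so compound 1 offers only a limit as a starting point and no measured step is available for comparison.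

Compound 3, `C=C[C@@](C)(/C=C/c1ccc(Nc2cc(F)cc(F)c2)cc1)CCC=C(C)C`, keeps the core of compound 1 but carries (3,5-difluorophenyl)amino in place of methoxy on an aromatic carbon, para to a large group: (3,5-difluorophenyl)amino in place of methoxy on an aromatic carbon. Within the data shown here, no measured pair isolates this change, so its effect in this assay can only be judged tentatively. A moderate move towards lower concentrations, meaning that less compound is needed, is expected, given how much larger the entering group is, although compound 3 may well stay at the limit too. The expected change is an at least 2.0-fold lower number from compound 1 to compound 3 (0.30 log units; that floor lies within the scatter). The estimated value for compound 3 is 18000 nM, with an expected range of 6000 nM to 36600 nM.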

Compound 3, half-maximal effective concentration: > 36600 nM
Compound 3 ended at the assay's limit; the forecaster's own chance of this, stated with the estimate: 45%; at least 2.0-fold (0.30 log units) between middle value and limit.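

Compound 3 gives > 36600 nM in this assay, which is a limit and not a number. Compound 1 also stands at a limit, so the step between compound 1 and compound 3 cannot be read. The compounds shown leave open how much of any of them is needed for the effect, and whether (3,5-difluorophenyl)amino in place of methoxy changes that amount at all: the limit of > 36600 nM in this assay, at which 3 of the 3 values shown sit.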